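This account rests on a few compounds, and the source may have more. Where it says the series, first, only, none or still open, it means among the compounds named here.

Working notes on the series. In a functional assay on COLO 205 cells (Homo sapiens) for inhibition, read by sulforhodamine B assay (on this read-out higher numbers stand for weaker inhibition of growth and lower numbers for stronger inhibition of growth), compound 1 `c1ccc(-c2ccc(-c3ccc(-c4nc5ccccc5[nH]4)cc3)cc2)cc1` gives 100000 nM, level with compound 3 `FC(F)(F)Oc1ccc(-c2ccc(-c3ccc(-c4nc5ccccc5[nH]4)cc3)cc2)cc1` at 100000 nM, and the two together hold the highest of the three numbers. Compound 2 `FC(F)(F)c1ccc(-c2ccc(-c3ccc(-c4nc5ccccc5[nH]4)cc3)cc2)cc1` sits lower at 33900 nM.

Compound 4 `Cc1ccc2[nH]c(-c3ccc(-c4ccc(-c5ccccc5)cc4)cc3)nc2c1` differs from compound 1 by one change: methyl in place of hydrogen on an aromatic carbon. Within the data shown here, no measured compound carries a group on that ring, so the evidence is indirect. Among the measured compounds shown here, two steps bear on it: a 2.9-fold lower number from compound 1 to compound 2 (0.47 log units; beyond the scatter), a modest one with trifluoromethyl, and no change at the digits printed from compound 1 to compound 3 (within the scatter), with trifluoromethoxy. The step between those two groups is a 2.9-fold higher number from compound 2 to compound 3 (0.47 log units; beyond the scatter). Single substitutions on compound 1 have therefore moved this assay little or not at all, and only towards lower numbers.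

The expectation is a small shift towards a lower number, not clearly beyond the scatter. The estimated change is a 1.4-fold lower number from compound 1 to compound 4 (0.15 log units; within the scatter). For compound 4 the expected value is 70000 nM, with an estimated range of 30000 nM to 100000 nM.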

Compound 4, concentration for 50% growth inhibition: 2560 nM
Compound 4: the middle estimate sits 27-fold (1.44 log units) above what was measured; the whole stated range lies above it.
By their numbers in this assay, from the lowest: compound 4; then compound 2; then compounds 1 and 3 (each within the scatter of the next).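

In this assay, the methyl on the six-membered aromatic ring of carbon only, part of the fused system, gives a 39-fold lower number from compound 1 to compound 4 (1.59 log units; beyond the scatter). A change of a single heavy atom at this position thus moves the read-out much further than the trifluoromethyl and trifluoromethoxy changes on the other side of the comparison, which give a 2.9-fold lower number from compound 1 to compound 2 (0.47 log units; beyond the scatter) and no change at the digits printed from compound 1 to compound 3 (within the scatter). No measurement offered here accounts for the size of the methyl step.

The compounds shown leave open whether this step is particular to methyl or would also appear with an ethyl group, a chlorine atom, an amine or a carboxylic acid on the same carbon. They also leave open whether the methyl and the trifluoromethyl would add up in one compound.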